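Clearance after hydroxylating a propynyl group

The source may report more compounds than this note shows. Statements on the series, on what has been measured and on what is new or still open speak of the compounds shown alone.

Compound 1 `Nc1ccc(S(=O)(=O)c2ccc(-c3ccc(C(O)(C(F)(F)F)C(F)(F)F)cn3)cc2)cn1`: < 14 mL.min-1.g-1
Compound 2 `CC#Cc1cc(C(O)(C(F)(F)F)C(F)(F)F)cnc1-c1ccc(S(=O)(=O)c2ccc(N)nc2)cc1`: 177 mL.min-1.g-1

Within the data shown here, in an ADME assay (liver) for metabolic stability, with Liver microsome (Rattus norvegicus) as the target, using microsomes and NADPH, with a stated time of 30 min, at 37 degrees C, tested at 1 uM (on this read-out higher numbers stand for fast clearance and lower numbers for slow clearance), compound 2 gives 177 mL.min-1.g-1, the only true number so far. Compound 1 gives < 14 mL.min-1.g-1, which is a limit of the assay and not a number.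

Compound 3 `Nc1ccc(S(=O)(=O)c2ccc(-c3ncc(C(O)(C(F)(F)F)C(F)(F)F)cc3C#CCO)cc2)cn1` differs from compound 2 by hydroxy in place of hydrogen on a saturated chain carbon bound to a triple-bonded carbon: methyl to hydroxymethyl, which turns prop-1-yn-1-yl into 3-hydroxyprop-1-yn-1-yl.

Among the measured compounds shown here, one measured step bears on this, an at least 12-fold higher number from compound 1 to compound 2 (1.10 log units; beyond the scatter), with prop-1-yn-1-yl in place of hydrogen on an aromatic carbon. For the measured compounds named here, that large step rests on (the limit of < 14 mL.min-1.g-1 in this assay, at which 1 of the 2 values shown sits), and no measured step tests the hydroxy itself. The change falls on the same group, so part of that rise is expected to be lost, and the expected step is moderate and downward: a 3.0-fold lower number from compound 2 to compound 3 (0.47 log units; beyond the scatter). For compound 3 the estimate is 60 mL.min-1.g-1, with an expected range from 20 mL.min-1.g-1 to 160 mL.min-1.g-1.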

Compound 3, intrinsic clearance in microsomes: 36 mL.min-1.g-1
Estimate against measurement, compound 3: 1.7-fold (0.22 log units) above; low and high end bracket the measured number.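

In this assay, hydroxy on the saturated chain carbon bound to a triple-bonded carbon takes back a large part of the rise that prop-1-yn-1-yl had brought: a 4.9-fold lower number from compound 2 to compound 3 (0.69 log units; beyond the scatter). The high clearance of compound 2 is therefore not fixed by the triple bond at this position, since a change at the end of the chain alone moves the number. Yet 3-hydroxyprop-1-yn-1-yl in place of hydrogen on the aromatic carbon still leaves the number raised, an at least 2.5-fold higher number from compound 1 to compound 3 (0.41 log units; beyond the scatter), and the true size of that step stays open: the limit of < 14 mL.min-1.g-1 in this assay, at which 1 of the 3 values shown sits.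

The compounds shown leave open whether the fall depends on the hydroxy itself or on any replacement of the methyl end, which a methoxymethyl or an aminomethyl group would help to separate. They also do not tell where on compound 3 the remaining clearance arises.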